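Cyclohexyl carbamate biphenyls: benzyl to hydroxyethyl

The source may report more compounds than this note shows. Statements on the series, on what has been measured and on what is new or still open speak of the compounds shown alone.

Measured so far:
compound 1 `O=C(NC1CCCCC1)Oc1cccc(-c2ccc(F)cc2)c1` — 65 nM
compound 2 `O=C(NC1CCCCC1)Oc1cccc(-c2cccc(Cc3ccccc3)c2)c1` — 1860 nM

In an assay on cell membranes for binding affinity to Fatty-acid amide hydrolase 1 (Rattus norvegicus) (a lower number here means a stronger inhibitor, a higher number a weaker inhibitor), compound 2 gives the higher of the two numbers, with the gap to compound 1 at 65 nM beyond the scatter. Compound 3 `O=C(NC1CCCCC1)Oc1cccc(-c2cccc(CCO)c2)c1` differs from compound 2 by hydroxymethyl in place of phenyl on a saturated chain carbon bound to an aromatic carbon. Within the data shown here, no measured pair isolates this kind of change, so the direction rests on the contrast between the two known points: because compound 2 gives 1860 nM while compound 1 gives 65 nM, a step downward beyond the scatter is expected, a 4.7-fold lower number from compound 2 to compound 3 (0.67 log units; beyond the scatter). Compound 3 is estimated at 400 nM, with a range from 120 nM to 1500 nM.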

Compound 3, half-maximal inhibitory concentration: 18.7 nM
Beside the measured number, compound 3's estimate is 21-fold (1.33 log units) above it, and the stated range ends above it.
By their numbers in this assay, from the lowest: compound 3; then compound 1; then compound 2.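

In this assay, the change from benzyl to 2-hydroxyethyl gives a 99-fold lower number from compound 2 to compound 3 (2.00 log units; beyond the scatter) and is large, so this position responds strongly to the group it carries. Compound 2 alone left open whether substitution here was simply poorly accepted, whereas compound 3 shows that a hydroxymethyl on the saturated chain carbon is well accepted. Nothing on hand accounts for the size of this step. Still open, on these data alone, is whether the gain follows from the hydroxyl or from the loss of the phenyl. An ethyl, a 2-methoxyethyl, a carboxylic acid, an amine or a longer chain ending in hydroxyl would help separate the two.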